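Halogen swap beside the methanesulfonamide in the series

This account rests on a few compounds, and the source may have more. Where it says the series, first, only, none or still open, it means among the compounds named here.

The two measured compounds share one core. Compound 1 `CC(C(=O)NCc1ccc(C(C)(C)C)cc1)c1ccc(NS(C)(=O)=O)cc1` carries hydrogen on the aromatic carbon in question, and in an assay on CHO cells for displacement of a labelled ligand from transient receptor potential cation channel subfamily V member 1 (Rattus norvegicus), read by scintillation counting, with a stated time of 60 min (on this read-out lower numbers stand for stronger inhibition and higher numbers for weaker inhibition), compound 1 gives 106 nM. Compound 2 `CC(C(=O)NCc1ccc(C(C)(C)C)cc1)c1ccc(NS(C)(=O)=O)c(Cl)c1` carries chloro there, and in this assay compound 2 gives 30.7 nM. Going by the values given here, compound 2 therefore holds the lowest of the two numbers, the step of a 3.5-fold lower number from compound 1 to compound 2 (0.54 log units; beyond the scatter) being the only measured step in the set.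

Compound 3 `CC(C(=O)NCc1ccc(C(C)(C)C)cc1)c1ccc(NS(C)(=O)=O)c(Br)c1` differs from compound 2 by bromo in place of chloro on an aromatic carbon, on an aromatic carbon of a six-membered aromatic ring of carbon only, ortho to a methanesulfonamido group and meta to a large group. Among the compounds with values here, no measured step exchanges one halogen for another; the single step of a 3.5-fold lower number from compound 1 to compound 2 (0.54 log units; beyond the scatter) shows only that placing chloro at this carbon lowered the number. For the exchange of chloro for bromo a step within the scatter is expected in this assay, with a slight lean toward a lower number, the expected step being a 1.2-fold lower number from compound 2 to compound 3 (0.09 log units; within the scatter). Compound 3 is estimated at 25 nM in this assay, within a range of 10 nM to 70 nM.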

Compound 3, inhibition constant: 7.4 nM
Compound 3: middle estimate off by 3.4-fold (0.53 log units), on the high side; the measured number lies below the stated range.
By their numbers in this assay, from the lowest: compound 3; then compound 2; then compound 1.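

At the aromatic carbon ortho to a methanesulfonamido group, the identity of the halogen matters as well as its presence: in this assay, bromo in place of chloro gives a 4.1-fold lower number from compound 2 to compound 3 (0.62 log units; beyond the scatter) and so forms a step of its own beyond the scatter. Bromo in place of hydrogen gives a 14-fold lower number from compound 1 to compound 3 (1.16 log units; beyond the scatter) as a large step, whereas chloro in place of hydrogen gives a 3.5-fold lower number from compound 1 to compound 2 (0.54 log units; beyond the scatter) as a modest one, and the number falls from hydrogen to chloro to bromo with none of these three compounds going against that order. Nothing available explains the difference between bromo and chloro at this carbon.

Going by these compounds, whether iodo at this carbon continues the order remains open, as does whether fluoro, methyl or methoxy there would fit it. Also open, on these data alone, is whether the step from chloro to bromo carries over when a carboxylic acid takes the place of the methanesulfonamido group.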